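Trifluoromethyl for chloro on the urea aryl of compound 1

The compounds below may be only part of what the source reports. "The series", "measured", "known", "first", "only" and "open" are said of these compounds alone.

compound 1 `COc1cc(-c2nn(-c3cccc(NC(=O)Nc4ccc(Cl)c(Cl)c4)c3)cc2-c2ccncc2)ccc1Cl` > 50000 nM
compound 2 `O=C(Nc1cccc(-n2cc(-c3ccncc3)c(-c3ccc(Cl)c(O)c3)n2)c1)Nc1ccc(Cl)c(Cl)c1` 29600 nM
compound 3 `O=C(Nc1cccc(-n2cc(-c3ccncc3)c(-c3ccc(Cl)c(O)c3)n2)c1)Nc1cc(C(F)(F)F)cc(C(F)(F)F)c1` 3520 nM

In a functional assay on HCT-15 cells (Homo sapiens) for inhibition, read by sulforhodamine B assay, with a stated time of 48 h (a lower number here means a stronger inhibitor of growth, a higher number a weaker inhibitor of growth), compound 1 gives only a limit, > 50000 nM, and sits at the limit of > 50000 nM in this assay, at which 1 of the 3 values shown sits. Compound 2 gives 29600 nM in this assay. Going by the values given here, the one measured step, an at least 1.6-fold lower number from compound 1 to compound 2 (0.22 log units; that floor lies within the scatter), is the only change in the shared core with a number attached. Compound 3 gives 3520 nM; set against compound 2, the two values show a lower number for compound 3.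

Compound 4 `COc1cc(-c2nn(-c3cccc(NC(=O)Nc4ccc(Cl)c(C(F)(F)F)c4)c3)cc2-c2ccncc2)ccc1Cl` differs from compound 1 by trifluoromethyl in place of chloro on an aromatic carbon. Among the compounds with values here, no measured step follows this change, and the only anchor for it is a limit. Compound 4 is expected near 40000 nM, between 10000 nM and 100000 nM. For compound 4 that estimate means an expected step of an at least 1.2-fold lower number from compound 1 to compound 4 (0.09 log units; that floor lies within the scatter), which stays close to the limit.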

Compound 4, concentration for total growth inhibition: 7050 nM
Beside the measured number, compound 4's estimate is 5.7-fold (0.75 log units) above it, and the stated range ends above it.
By their numbers in this assay, from the lowest: compounds 3 and 4 (each within the scatter of the next); then compound 2. At a limit, above all of these: compound 1.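

In this assay, trifluoromethyl in place of chloro on an aromatic carbon of the 3,4-dichlorophenyl gives an at least 7.0-fold lower number from compound 1 to compound 4 (0.85 log units; beyond the scatter). Going by these compounds alone, this is the first change on that ring with a step that can be read, and the earlier step, at the methyl on an oxygen, had its floor within the scatter. Compound 1 stands only at a limit, so the step is a floor and its full size stays unknown: the limit of > 50000 nM in this assay, at which 1 of the 4 values shown sits.

Still open, from the compounds shown here alone, is whether the same change gives a like step from compound 2. Also open, going by these compounds, is what an amine or a nitrile would give at this position.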